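A few compounds are considered here, and "the series" means these few. Any claim that something is new, unique, unknown or untested is made for them only; others in the source may bear on it.

In a toxicity assay on MT4 cells (Homo sapiens) for cytotoxicity, read by MTT assay, with a stated time of 5 days (a lower number here means that less compound is tolerated, a higher number that more compound is tolerated), compound 3 (`Cc1cc(-c2ccnc(F)c2)cc(C)c1Nc1ccnc(Nc2ccc(C#N)cc2)n1`) gives the highest of the three numbers at 6000 nM, with compound 1 (`Cc1cc(-c2ccco2)cc(C)c1Nc1ccnc(Nc2ccc(C#N)cc2)n1`) at 1700 nM and compound 2 (`Cc1cc(-c2cccc3cc[nH]c23)cc(C)c1Nc1ccnc(Nc2ccc(C#N)cc2)n1`) at 1000 nM. The next change leads to compound 4 (`Cc1cc(-c2cnc(C(F)(F)F)nc2)cc(C)c1Nc1ccnc(Nc2ccc(C#N)cc2)n1`), which carries 2-(trifluoromethyl)pyrimidin-5-yl in place of 2-fluoropyridin-4-yl on an aromatic carbon.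

All three measured steps exchange the group at this same place, so all three bear on the change. The two that end at compound 3 are modest: a 3.5-fold higher number from compound 1 to compound 3 (0.55 log units; beyond the scatter) and a 6.0-fold higher number from compound 2 to compound 3 (0.78 log units; beyond the scatter). The third, a 1.7-fold lower number from compound 1 to compound 2 (0.23 log units; within the scatter), stays within the scatter. None of them tests the entering group directly. Compound 4 keeps a single six-membered aromatic ring at this place, as compound 3 does, so the number in this assay should stay near that of compound 3 or fall slightly towards the other two. The expected change is a 1.5-fold lower number from compound 3 to compound 4 (0.18 log units; within the scatter), which means no clear step beyond the scatter is expected. For compound 4 the estimate is 4000 nM, with an expected range from 1300 nM to 12000 nM.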

Compound 4, half-maximal cytotoxic concentration: 4900 nM
The estimate for compound 4 lay 1.2-fold (0.09 log units) below the measured number, and the stated range covers the measured number.
By their numbers in this assay, from the lowest: compounds 2 and 1 (each within the scatter of the next); then compounds 4 and 3 (each within the scatter of the next).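

In this assay, exchanging 2-fluoropyridin-4-yl for the larger 2-(trifluoromethyl)pyrimidin-5-yl gives a 1.2-fold lower number from compound 3 to compound 4 (0.09 log units; within the scatter), so this position accepts the added trifluoromethyl and a second ring hetero atom without a clear shift in this read-out. The entering group also gives a 2.9-fold higher number from compound 1 to compound 4 (0.46 log units; beyond the scatter) and a 4.9-fold higher number from compound 2 to compound 4 (0.69 log units; beyond the scatter), so among these four compounds both groups with a single six-membered aromatic ring give higher numbers than furan-2-yl and 1H-indol-7-yl, and no compound shown goes against this. No supporting data explain these differences.

From the compounds shown here alone, it remains open whether a plain phenyl group, with no ring hetero atom, would stay within the scatter of compound 3 and compound 4. Going by these compounds, the effect of a morpholine or a carboxylic acid at this position is also open.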